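Indole-vinyl sulfone series: acetyl in place of benzoyl

The source may hold more compounds than are shown below. What is called first, only, known or untested is meant among the compounds shown, and "the series" means these compounds.

Measured so far:
compound 1 `CCOC(=O)C(=Cc1c(-c2ccccc2)[nH]c2ccccc12)C(=O)OCC` 3100 nM
compound 2 `O=C(/C(=C\c1c(-c2ccccc2)[nH]c2ccccc12)S(=O)(=O)c1ccccc1)c1ccccc1` 4200 nM
compound 3 `COc1ccc(-c2[nH]c3ccc(OC)cc3c2/C=C(\C#N)S(=O)(=O)c2ccccc2)cc1` 1300 nM

All three were tested in a functional assay on MDA-MB-468 cells (Homo sapiens) for inhibition, read by sulforhodamine B assay, with a stated time of 48 h; a higher number here means a weaker inhibitor of growth, a lower number a stronger inhibitor of growth. Compound 2 has the highest number of the three. The nearest is compound 1, and the two values of compound 1 and compound 2 lie within the scatter of each other, so no order can be read between them. The furthest is compound 3, whose value lies beyond the scatter from that of compound 2; compound 3 thus gives the lower number of the pair.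

Compound 4 `CC(=O)/C(=C\c1c(-c2ccccc2)[nH]c2ccccc12)S(=O)(=O)c1ccccc1` has not been measured. It differs from compound 2 in one place: methyl in place of phenyl on a carbonyl carbon. Cut one bond further out, the change reads benzoyl to acetyl.

Among the compounds with values here, no step between measured compounds that differ in one place is available, so there is nothing to scale this change against. The expectation is a step of no size beyond the scatter in this assay, with the direction left open. Compound 4 is accordingly estimated at 4500 nM, with a range from 2000 nM to 10000 nM. The step this estimate means is a 1.1-fold higher number from compound 2 to compound 4 (0.03 log units; within the scatter), expected to remain within the scatter.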

Compound 4, concentration for 50% growth inhibition: 1700 nM
For compound 4 the middle estimate is 2.6-fold (0.42 log units) above the measured one; the measured number lies below the stated range.
By their numbers in this assay, from the lowest: compounds 3, 4, 1 and 2 (each within the scatter of the next, the first and the last beyond it).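

In this assay, within the data shown here, the carbonyl carbon is the first place where a change can be read on its own: methyl in place of phenyl gives a 2.5-fold lower number from compound 2 to compound 4 (0.39 log units; beyond the scatter), a modest step. The benzoyl phenyl is therefore not required for growth inhibition in this assay, since the acetyl compound, with one carbon in place of a six-membered aromatic ring, is the stronger of this pair. The earlier compounds could not show this, as none of them formed a one-place pair, and nothing measured here accounts for the direction of the step.

With only phenyl and methyl on this carbonyl carbon, the compounds shown cannot tell whether the step tracks the loss of the aromatic ring or the loss of heavy atoms, a question that ethyl, a longer chain, a cyclohexyl ring or an amine at the same place would address. As far as these compounds go, it also remains open whether benzoyl to acetyl gives a step of similar direction on other cores, such as the dimethoxy-substituted core of compound 3.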